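Swapping the aryl group on a weakly active chalcone core

A few compounds are considered here, and "the series" means these few. Any claim that something is new, unique, unknown or untested is made for them only; others in the source may bear on it.

Measured so far:
Compound 1, `CCOc1ccc(/C=C(/Sc2ccccc2Cl)C(=O)c2ccc(Cl)cc2)cc1OC`: 50000 nM
Compound 2, `CCOc1ccc(/C=C(\C(=O)c2ccc(Cl)cc2)S(=O)(=O)Cc2ccc(C)cc2)cc1OC`: 10000 nM

In a functional assay on DU-145 cells (Homo sapiens) for inhibition, read by trypan blue exclusion, with a stated time of 96 h (on this read-out higher numbers stand for weaker inhibition of growth and lower numbers for stronger inhibition of growth), compound 2 gives the lowest of the two numbers; its nearest neighbour, compound 1, lies a 5.0-fold lower number from compound 1 to compound 2 (0.70 log units; beyond the scatter) away, so compound 2 is the stronger grower inhibitor of the pair. The unmeasured compound 3, `Cc1ccc(CS(=O)(=O)/C(=C/c2ccc(C)s2)C(=O)c2ccc(Cl)cc2)cc1`, keeps the (4-methylbenzyl)sulfonyl group of compound 2 and changes the aryl group at the other end of the double bond instead: 5-methylthiophen-2-yl in place of 4-ethoxy-3-methoxyphenyl on a double-bonded chain carbon bound to a double-bonded chain carbon. Among the measured compounds shown here, the only step measured so far, a 5.0-fold lower number from compound 1 to compound 2 (0.70 log units; beyond the scatter), concerns the sulfur-bearing group and not this aryl position, so nothing measured bears directly on the change from compound 2 to compound 3. With no guide in either direction, the expected step of no change at the digits printed from compound 2 to compound 3 (within the scatter) in this assay is none beyond the scatter, and the expected result for compound 3 is 10000 nM with a range of 2500 nM to 40000 nM.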

Compound 3, concentration for 50% growth inhibition: 25000 nM
Estimate against measurement, compound 3: 2.5-fold (0.40 log units) below; measured number inside the range.
By their numbers in this assay, from the lowest: compound 2; then compounds 3 and 1 (each within the scatter of the next).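

In this assay, the aryl group on a double-bonded chain carbon bound to a double-bonded chain carbon also affects growth inhibition: 5-methylthiophen-2-yl in place of 4-ethoxy-3-methoxyphenyl gives a 2.5-fold higher number from compound 2 to compound 3 (0.40 log units; beyond the scatter), a modest loss. Among the compounds shown here, the earlier step concerned only the sulfur-bearing group, so this is the first sign that the other end of the double bond responds too, with 4-ethoxy-3-methoxyphenyl the better of the two groups compared here. No measurement shown offers a reason for this step.

Going by these compounds, it remains open whether the loss follows the change of ring or the removal of the ethoxy and methoxy groups, as both change together in this single step. A plain phenyl or a 4-methoxyphenyl group at this place would help to separate the two, and a ring bearing an amine would test a different kind of substituent.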